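Swapping Acetoxy for Chloro on a Short Side Chain

The source may hold more compounds than are shown below. What is called first, only, known or untested is meant among the compounds shown, and "the series" means these compounds.

Compound 1 `CC(=O)OCCc1c(C)[nH]c(=O)[nH]c1=O` was tested in a functional assay on SW-620 cells (Homo sapiens) for antiproliferative activity, read by MTT assay, with a stated time of 24 h; on this read-out lower numbers stand for stronger inhibition and higher numbers for weaker inhibition. In this assay compound 1 gives > 100000 nM, which is a limit of the assay rather than a number. A second compound, compound 2 `COc1nc(Cl)nc(C)c1CCOC(C)=O`, is also known only by a limit: in this assay compound 2 gives > 100000 nM. Both results sit at the same point, (the limit of > 100000 nM in this assay, at which 2 of the 2 values shown sit), so compound 1 stands level with the other measured compound on the numbers shown. Compound 3 `Cc1[nH]c(=O)[nH]c(=O)c1CCCl` has not yet been measured. It differs from compound 1 in one place: chloro in place of acetoxy on a saturated chain carbon, two bonds along the chain from an aromatic carbon. Going by the values given here, no measured step between compounds is available to show how such a change acts in this assay, so no shift beyond the scatter is expected, and the step is estimated as a number no higher from compound 1 to compound 3 (the limit leaves the size open). Compound 3 is accordingly expected to give about 100000 nM in this assay, within a range from 30000 nM to 300000 nM.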

Compound 3, half-maximal inhibitory concentration: > 100000 nM
Compound 3: a limit, no number; the forecaster's own chance of this, stated with the estimate: 80%; the middle value lies on the limit itself.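

Going by these compounds alone, compound 1 and compound 3 both end at a limit of the assay rather than a number, so no step between them can be read in this assay: the limit of > 100000 nM in this assay, at which 3 of the 3 values shown sit.

The compounds shown leave open whether swapping acetoxy for chloro changes antiproliferative activity at all.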